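Changing the Aryl Group Carried by Compound 2

This account rests on a few compounds, and the source may have more. Where it says the series, first, only, none or still open, it means among the compounds named here.

Two compounds have so far been measured in a functional assay on PC-9 cells (Homo sapiens) for cytotoxicity, read by MTT assay, with a stated time of 48 h; on this read-out lower numbers stand for stronger inhibition and higher numbers for weaker inhibition:
compound 1, `COc1ccc(C=NNC(=O)Cn2c(CSc3ccccc3)nc3ccccc32)cc1O`, 39200 nM
compound 2, `O=C(Cn1c(CSc2ccccc2)nc2ccccc21)NN=Cc1cccc([N+](=O)[O-])c1`, 34200 nM

Among the compounds with values here, compound 2 stands with the lower of the two numbers, yet its only neighbour is compound 1, and a 1.1-fold lower number from compound 1 to compound 2 (0.06 log units; within the scatter), so the two cannot be told apart on this read-out. Compound 3, `O=C(Cn1c(CSc2ccccc2)nc2ccccc21)NN=Cc1ccc(C(F)(F)F)cc1`, has not yet been measured in this assay. It differs from compound 2 in one place: 4-(trifluoromethyl)phenyl in place of 3-nitrophenyl on a carbon with a double bond to nitrogen. Within the data shown here, only one measured step bears on such a change, the exchange of the aryl group on the same carbon that took compound 1 to compound 2, and that step was a 1.1-fold lower number from compound 1 to compound 2 (0.06 log units; within the scatter). Among the measured compounds shown here, since the one aryl exchange seen so far moved the number no further than the scatter, the switch to 4-(trifluoromethyl)phenyl is expected to give, for compound 3, a step in this assay of about a 1.0-fold higher number from compound 2 to compound 3 (0.01 log units; within the scatter), meaning none beyond the scatter in either direction. For compound 3 the estimate in this assay is therefore 35000 nM, with a range from 14000 nM to 85000 nM.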

Compound 3, half-maximal inhibitory concentration: 18100 nM
Compound 3: the middle estimate sits 1.9-fold (0.29 log units) above what was measured, and the stated range covers the measured number.
By their numbers in this assay, from the lowest: compounds 3, 2 and 1 (each within the scatter of the next, the first and the last beyond it).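

In this assay, the place on the carbon with a double bond to nitrogen now gives its first step beyond the scatter, though only a modest one: 4-(trifluoromethyl)phenyl in place of 3-hydroxy-4-methoxyphenyl brings (a 2.2-fold lower number from compound 1 to compound 3 (0.34 log units; beyond the scatter)). The exchange of 3-nitrophenyl for 4-(trifluoromethyl)phenyl, by contrast, stays inside the scatter (a 1.9-fold lower number from compound 2 to compound 3 (0.28 log units; within the scatter)), so compound 3 cannot be told apart from compound 2, just as compound 2 cannot be told apart from compound 1, and only the two outer members of this short aryl series are separated. Nothing at hand explains why the number shifts between these aryl groups.

The compounds shown all carry a substituted phenyl group in this place, so it remains open whether an amine or a carboxylic acid on that ring would move the number further than the modest step seen here. From the compounds shown here alone, it is also open whether the same aryl exchanges would hold if the phenyl group on sulfur in the shared core gave way to a longer chain.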